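The compounds below may be only part of what the source reports. "The series", "measured", "known", "first", "only" and "open" are said of these compounds alone.

In an in vitro assay on HEK385-7 cells for displacement of a labelled ligand from prostaglandin D2 receptor 2 (Homo sapiens) (a lower number here means a stronger inhibitor, a higher number a weaker inhibitor), compound 3 `O=C(O)Cc1sc(C(c2ccc(F)cc2)c2ccc(F)cc2)nc1-c1ccco1` gives 18 nM, the lowest of the two numbers recorded there. Compound 1 `O=C(O)Cc1sc(COc2ccc(Cl)cc2)nc1-c1ccc(Cl)cc1` gives 32 nM in this assay, and this number lies within the usual scatter of the number for compound 3, so the two cannot be put in order. Compound 2 `Nc1nc(-c2ccc(Cl)cc2)c(CC(=O)O)s1` reaches only a limit of this assay, > 100000 nM, which is a limit and not a number; (the limit of > 100000 nM in this assay, at which 1 of the 3 values shown sits). Compound 4 `O=C(O)Cc1sc(C(c2ccc(F)cc2)c2ccc(F)cc2)nc1-c1cn[nH]c1` has not yet been measured in this assay. It differs from compound 3 in a single place: 1H-pyrazol-4-yl in place of furan-2-yl on an aromatic carbon. Among the measured compounds shown here, no measured pair here shows a change of this kind, so the size of the step is not fixed by the data. The step from compound 3 to compound 4 is expected to be small, a 2.2-fold higher number from compound 3 to compound 4 (0.35 log units; beyond the scatter), and may well stay within the scatter. Compound 4 is therefore estimated at 40 nM in this assay, with a likely range from 12 nM to 130 nM.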

Compound 4, half-maximal inhibitory concentration: 16 nM
The estimate for compound 4 lay 2.5-fold (0.40 log units) above the measured number; the measured number falls inside the stated range.
By their numbers in this assay, from the lowest: compounds 4, 3 and 1 (each within the scatter of the next). At a limit, above all of these: compound 2.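

In this assay, this is the first change shown at the aromatic carbon next to the ring nitrogen and next to the ring atom that bears a carboxymethyl group: a 1.1-fold lower number from compound 3 to compound 4 (0.05 log units; within the scatter). The step lies within the scatter, so at this place 1H-pyrazol-4-yl, which carries a hydrogen-bond donor and a second ring nitrogen, cannot be told apart from furan-2-yl, which has no donor. No measurement shown bears on why the two groups cannot be separated.

On these data alone, it remains open whether the hydrogen on the pyrazole nitrogen matters at all, which a 1-methyl-1H-pyrazol-4-yl group at this place would test. As far as these compounds go, it is also open whether a group that is not aromatic, such as piperidin-4-yl or a simple amine, would fit here as well as these two rings.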